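Methoxy Position Shift on the Hydrazone Aryl Group

The compounds below may be only part of what the source reports. "The series", "measured", "known", "first", "only" and "open" are said of these compounds alone.

The series shares a core carrying an acrylamide side chain and a hydrazone-linked aryl ring. Compound 1, `C/C(=N\Nc1ncc(Cl)c(Nc2cccc(NC(=O)/C=C/CN(C)C)c2)n1)c1ccc(C)cc1`, gives 11800 nM in an ADME assay on HT-29 cells (Homo sapiens) for inhibition, read by MTT assay, with a stated time of 72 h; a lower number here means a stronger inhibitor, a higher number a weaker inhibitor. Compound 2, `COc1ccc(/C(C)=N/Nc2ncc(Cl)c(Nc3cccc(NC(=O)/C=C/CN(C)C)c3)n2)cc1`, gives 6830 nM in this assay. Among the compounds with values here, the single recorded step, a 1.7-fold lower number from compound 1 to compound 2 (0.24 log units; within the scatter), does not separate the two. Compound 2 therefore holds the lowest of the two numbers, but only within the scatter of compound 1.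

Compound 3, `COc1cccc(/C(C)=N/Nc2ncc(Cl)c(Nc3cccc(NC(=O)/C=C/CN(C)C)c3)n2)c1`, differs from compound 2 as follows: 3-methoxyphenyl in place of 4-methoxyphenyl on a carbon with a double bond to nitrogen. Within the data shown here, no measured step bears on a shift of the methoxy group around the ring; the one step available concerns methyl against methoxy and is itself within the scatter. With nothing to indicate a direction, the step of a 1.1-fold higher number from compound 2 to compound 3 (0.04 log units; within the scatter) is expected to stay within the scatter. Compound 3 is estimated at 7500 nM in this assay, with a range from 3000 nM to 19000 nM.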

Compound 3, half-maximal inhibitory concentration: 3870 nM
The estimate for compound 3 lay 1.9-fold (0.29 log units) above the measured number; measured number inside the range.
By their numbers in this assay, from the lowest: compounds 3, 2 and 1 (each within the scatter of the next, the first and the last beyond it).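

On the carbon with a double bond to nitrogen, 3-methoxyphenyl and 4-methoxyphenyl are not separated in this assay (a 1.8-fold lower number from compound 2 to compound 3 (0.25 log units; within the scatter)). Within the data shown here, the replacement of 4-methylphenyl by 3-methoxyphenyl gives the first step beyond the scatter, though only a modest one (a 3.0-fold lower number from compound 1 to compound 3 (0.48 log units; beyond the scatter)), so the aryl group at this place can move the number, while neither single comparison with the 4-methylphenyl or 4-methoxyphenyl compound does so alone. Nothing on hand accounts for these numbers.

That step changes both the group and its place on the ring, and 3-methylphenyl would be needed to tell the two apart. Also open, on these data alone, is whether an amine or a carboxylic acid on this ring gives a step beyond the scatter from compound 3.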